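This account rests on a few compounds, and the source may have more. Where it says the series, first, only, none or still open, it means among the compounds named here.

Three related compounds have been measured so far. In an ADME assay on the whole organism (Rattus norvegicus) for pharmacokinetics, at a dose of 0.5 mg/kg by the intravenous route (a higher number here means faster removal of the compound, a lower number slower removal), compound 1 (`CNC(=O)N(c1ccc(S(=O)(=O)Nc2ccon2)cn1)c1ccc(-c2ccc(Cl)c(C)c2)cc1OC`) gives 6130 mL/min/kg and compound 2 (`CNC(=O)N(c1ccc(S(=O)(=O)Nc2ccon2)cn1)c1cc(Cl)c(-c2cc(F)c(F)c(F)c2)cc1OC`) gives 4770 mL/min/kg. Compound 3 (`CNC(=O)N(c1ccc(S(=O)(=O)Nc2ncccn2)cn1)c1cc(F)c(-c2cccc(C(F)(F)F)c2)cc1OC`) gives 267 mL/min/kg, the lowest of the three numbers and beyond the usual scatter from both of the others.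

Compound 4 (`CNC(=O)N(c1ccc(S(=O)(=O)Nc2ncccn2)cn1)c1cc(F)c(-c2ccc(F)c(C(F)(F)F)c2)cc1OC`) differs from compound 3 in one place: fluoro in place of hydrogen on an aromatic carbon. This is fluoro in place of hydrogen on an aromatic carbon, which turns 3-(trifluoromethyl)phenyl into 4-fluoro-3-(trifluoromethyl)phenyl. Going by the values given here, no two measured compounds differ in only one place, so the data give no direct measure of such a change in this assay. The gap between compound 3 and the other two spans several structural differences at once and cannot be assigned to any one of them.

Among the compounds with values here, with only this single change, compound 4 is expected to stay close to compound 3 at 267 mL/min/kg, with no step beyond the scatter in either direction. The expected step is a 1.1-fold lower number from compound 3 to compound 4 (0.03 log units; within the scatter). Compound 4 is estimated at 250 mL/min/kg, with an expected range from 115 mL/min/kg to 560 mL/min/kg.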

Compound 4, clearance in the Rattus norvegicus assay: 817 mL/min/kg
Estimate against measurement, compound 4: 3.3-fold (0.51 log units) below, outside the stated range (above it).
By their numbers in the Rattus norvegicus assay, from the lowest: compound 3; then compound 4; then compounds 2 and 1 (each within the scatter of the next).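

the Rattus norvegicus assay now has its first step between compounds that differ in one place: compound 3 gives 267 mL/min/kg and compound 4 gives 817 mL/min/kg, and that step is a 3.1-fold higher number from compound 3 to compound 4 (0.49 log units; beyond the scatter). Going by these compounds alone, it shows that on this aromatic carbon, ortho to a trifluoromethyl group and para to a large group, fluoro in place of hydrogen does move this read-out, which the earlier compounds could not show. In a physicochemical assay for lipophilicity, at pH 7.4 (on this read-out higher numbers stand for higher lipophilicity and lower numbers for lower lipophilicity), compound 3 gives 1 and compound 4 gives 1.2, and the same pair gives a number 0.20 log units higher from compound 3 to compound 4 (within the scatter), so the two compounds cannot be told apart on that read-out, and nothing in the data accounts for the step in removal.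

As far as these compounds go, it remains open whether the step belongs to fluoro alone or would also appear with a nitrile or an amine on this carbon. From the compounds shown here alone, it is also open whether the same change would give a similar step on the core of compound 1 or compound 2.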